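The source may report more compounds than this note shows. Statements on the series, on what has been measured and on what is new or still open speak of the compounds shown alone.

Of the compounds shown here, three have so far been tested in a functional assay on T47D cells (Homo sapiens) for cytotoxicity, read by CCK-8 assay and cell counting, with a stated time of 2 days; on this read-out lower numbers stand for stronger inhibition and higher numbers for weaker inhibition. Compound 1 `Oc1ccc(-c2cc(-c3ccc(Cl)cc3)nc(-c3ccsc3)c2)cc1` gives 5490 nM. Compound 2 `Oc1cccc(-c2cc(-c3ccc(Cl)cc3)nc(-c3ccsc3)c2)c1` gives 11500 nM. Compound 3 `Oc1ccc(-c2cc(-c3ccccc3)nc(-c3cccc(Cl)c3)c2)cc1` gives 4790 nM.

Compound 1 and compound 2 share a core and differ by 3-hydroxyphenyl in place of 4-hydroxyphenyl on an aromatic carbon. That change made a 2.1-fold higher number from compound 1 to compound 2 (0.32 log units; beyond the scatter). Compound 3 rests on a different core; the difference between the two cores is not broken down here.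

Compound 4 `Oc1cccc(-c2cc(-c3ccccc3)nc(-c3cccc(Cl)c3)c2)c1` has not yet been measured. It differs from compound 3 by 3-hydroxyphenyl in place of 4-hydroxyphenyl on an aromatic carbon. Within the data shown here, this is the same kind of change as the one from compound 1 to compound 2, but its surroundings differ: in the earlier pair the changed group sits meta to a 4-chlorophenyl group and meta to a thiophen-3-yl group, whereas in compound 3 and compound 4 it sits meta to a 3-chlorophenyl group and meta to a phenyl group.

In this assay, among the measured compounds shown here, a step of a 2.1-fold higher number from compound 3 to compound 4 (0.32 log units; beyond the scatter) is expected, because the only earlier instance of this change gave a 2.1-fold higher number from compound 1 to compound 2 (0.32 log units; beyond the scatter). Compound 4 is therefore estimated at 10000 nM, most likely between 5000 nM and 20000 nM.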

Compound 4, half-maximal inhibitory concentration: 3700 nM
Compound 4: the middle estimate sits 2.7-fold (0.43 log units) above what was measured; measured number outside the range, below it.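

In this assay, 3-hydroxyphenyl in place of 4-hydroxyphenyl gave a 1.3-fold lower number from compound 3 to compound 4 (0.11 log units; within the scatter) and so made no readable difference on this core. Set beside the earlier pair, the same change did not carry over from one core to the other: the same change on two cores in this assay, a 2.1-fold higher number (0.32 log units; beyond the scatter) from compound 1 to compound 2 and a 1.3-fold lower number (0.11 log units; within the scatter) from compound 3 to compound 4, 2.7-fold (0.43 log units) apart, beyond the scatter of two such steps. This shows that the rise seen on the core of compound 1 cannot be assumed on a related core, but two pairs cannot show which difference between the cores matters, whether the 4-chlorophenyl group against the 3-chlorophenyl group or the thiophen-3-yl group against the phenyl group, nor how the change would behave on a third core.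

All the compounds shown carry a free hydroxyl on that phenyl ring, so it remains open how a methoxy group, an amine or a carboxylic acid in its place would read on either core. From the compounds shown here alone, it also remains open whether the two cores would part in the same way for those groups.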